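The source may report more compounds than this note shows. Statements on the series, on what has been measured and on what is new or still open speak of the compounds shown alone.

Measured compounds, all in a functional assay on MCF7 cells (Homo sapiens) for antiproliferative activity, read by MTT assay, with a stated time of 72 h; on this read-out higher numbers stand for weaker inhibition and lower numbers for stronger inhibition:

- compound 1, `CCN(CC)C/C=C/C(=O)Nc1cc2c(N3CCc4ccccc43)ncnc2cc1OC`: compound 1 gives 1990 nM
- compound 2, `COc1cc2ncnc(N3CCc4ccccc43)c2cc1NC(=O)/C=C/CN1CCCC1`: compound 2 gives 1510 nM
- compound 3, `CCN(CC)C/C=C/C(=O)Nc1cc2c(N3CCc4ccccc43)ncnc2cc1O[C@@H]1CCOC1`: compound 3 gives 4980 nM

Compound 1 and compound 2 share one core and differ only in the amine at the end of the unsaturated chain. That change is pyrrolidin-1-yl in place of diethylamino on a saturated chain carbon bound to a double-bonded chain carbon. Its effect in this assay is a 1.3-fold lower number from compound 1 to compound 2 (0.12 log units; within the scatter), so the two numbers are not distinguishable on this read-out.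

Compound 3 carries a different core: relative to compound 1 the difference is oxolan-3-yl in place of methyl on an oxygen on an aromatic ring. This second core gives the highest number of the three, with a 2.5-fold higher number from compound 1 to compound 3 (0.40 log units; beyond the scatter) separating it from compound 1; against compound 2 the gap is wider still, as the two values show.

Compound 4, `O=C(/C=C/CN1CCCC1)Nc1cc2c(N3CCc4ccccc43)ncnc2cc1O[C@@H]1CCOC1`, is not yet measured. It stands to compound 3 as compound 2 stands to compound 1: the change is pyrrolidin-1-yl in place of diethylamino on a saturated chain carbon bound to a double-bonded chain carbon, and the place given for it is the same, word for word, as for the pair of compound 1 and compound 2, so this is the same change on the core of compound 3. Within the data shown here, the only reference for what it does is the single earlier instance, a 1.3-fold lower number from compound 1 to compound 2 (0.12 log units; within the scatter), which lay within the scatter. Whether the amine swap behaves alike on the core of compound 3 cannot be checked from these data, so the expectation rests on that one step alone.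

The expected step from compound 3 to compound 4 in this assay is therefore small, about a 1.3-fold lower number from compound 3 to compound 4 (0.12 log units; within the scatter), because a 1.3-fold lower number from compound 1 to compound 2 (0.12 log units; within the scatter) was itself within the scatter. Compound 4 is estimated at 3800 nM, with a plausible range of 2000 nM to 7500 nM.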

Compound 4, half-maximal inhibitory concentration: 2310 nM
For compound 4 the middle estimate is 1.6-fold (0.22 log units) above the measured one; low and high end bracket the measured number.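

In this assay, pyrrolidin-1-yl in place of diethylamino gives a 2.2-fold lower number from compound 3 to compound 4 (0.33 log units; beyond the scatter), and the two instances of this change cannot be told apart in size: the same change on two cores in this assay, a 1.3-fold lower number (0.12 log units; within the scatter) from compound 1 to compound 2 and a 2.2-fold lower number (0.33 log units; beyond the scatter) from compound 3 to compound 4, 1.6-fold (0.21 log units) apart, within the scatter of two such steps. On the other axis, oxolan-3-yl in place of methyl on the oxygen gives a 1.5-fold higher number from compound 2 to compound 4 (0.18 log units; within the scatter), and this change also carries over without a separable difference: the same change on two cores in this assay, a 2.5-fold higher number (0.40 log units; beyond the scatter) from compound 1 to compound 3 and a 1.5-fold higher number (0.18 log units; within the scatter) from compound 2 to compound 4, 1.6-fold (0.21 log units) apart, within the scatter of two such steps. Within these four compounds, each change can therefore be treated as transferable between the two cores, but with only two instances of each, and one step of each pair within the scatter, this does not establish a fixed step size or extend to any other core.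

The compounds shown leave open whether another amine at the end of the chain, such as piperidin-1-yl, morpholin-4-yl or dimethylamino, or a longer chain carrying the amine, would fit the same picture. Going by these compounds, it also remains open whether a different group on the oxygen, such as a 2-methoxyethyl chain or a six-membered oxygen-containing ring, would behave as oxolan-3-yl does here.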